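The compounds below may be only part of what the source reports. "The series", "measured", "known", "first", "only" and "open" are said of these compounds alone.

Measured compounds:
compound 1, `Cc1ccc(C)c(-c2nc(CN3CCC(C(=O)NCCCN4C[C@H](C)C[C@H](C)C4)CC3)c(C)o2)c1`, 4070 nM
compound 2, `Cc1ccccc1-c1nc(CN2CCC(C(=O)NCCCN3CC(C)(C)CC(C)(C)C3)CC2)c(C)o1`, 4380 nM
compound 3, `Cc1oc(-c2c(Cl)cccc2Cl)nc1CN1CCC(C(=O)NCCCN2C[C@H](C)C[C@H](C)C2)CC1`, 13200 nM

In an ADME assay on Huh7.5.1 cells (Homo sapiens) for cytotoxicity, read by ATP content, with a stated time of 48 h (a higher number here means that more compound is tolerated, a lower number that less compound is tolerated), compound 2 stands second highest of the three; compound 1 gives a number within the scatter of it, and compound 3 gives the highest number of the set. Within the data shown here, the one step that is known, a 3.2-fold higher number from compound 1 to compound 3 (0.51 log units; beyond the scatter), concerns a change of the aryl group only and is modest in size.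

Compound 4, `Cc1ccccc1-c1nc(CN2CCC(C(=O)NCCCCN3C[C@H](C)C[C@H](C)C3)CC2)c(C)o1`, has not been measured. It differs from compound 2 in this way: a group of 9 heavy atoms (8 carbon, 1 nitrogen; one six-membered non-aromatic ring with 1 hetero atom) in place of a group of 10 heavy atoms (9 carbon, 1 nitrogen; one six-membered non-aromatic ring with 1 hetero atom), on a saturated chain carbon, three bonds along the chain from an amide-type nitrogen. Among the measured compounds shown here, no measured step touches that part of the molecule. What can be said is that compound 1 and compound 2, which differ both in the aryl group and in the substitution of the saturated ring at the end of the chain, give numbers within the scatter of each other, so nothing seen so far points to a sizeable shift from a change in that region.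

The expectation is therefore no step beyond the scatter, a 1.0-fold higher number from compound 2 to compound 4 (0.01 log units; within the scatter), with the estimate for compound 4 in this assay being 4500 nM, within a range from 2000 nM to 10000 nM.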

Compound 4, half-maximal cytotoxic concentration: 23100 nM
Compound 4: the middle estimate sits 5.1-fold (0.71 log units) below what was measured; measured number above the stated range.
By their numbers in this assay, from the lowest: compounds 1 and 2 (each within the scatter of the next); then compounds 3 and 4 (each within the scatter of the next).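

In this assay, replacing the group of 10 heavy atoms with (3,5-dimethylpiperidin-1-yl)methyl gives a 5.3-fold higher number from compound 2 to compound 4 (0.72 log units; beyond the scatter), with the rest of the molecule unchanged. This is the only step shown that touches this part of the molecule, on a saturated chain carbon, three bonds along the chain from an amide-type nitrogen, and it shows that a change here can move the number beyond the scatter. The aryl group is therefore no longer the only place known to matter, since the change there gives a 3.2-fold higher number from compound 1 to compound 3 (0.51 log units; beyond the scatter) and the new step is of a similar modest kind. Nothing available explains why the number rises, so the reason stays unknown.

Both groups hold one six-membered non-aromatic ring with 1 hetero atom, so this single step cannot tell which feature of the swap carries the shift. Also open, as far as these compounds go, is whether the same swap would give a similar step alongside the 2,6-dichlorophenyl group, and what a primary amine or a carboxylic acid would give in this place.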